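Cyano Added to a Methoxy-Bearing Spiro Compound

This account rests on a few compounds, and the source may have more. Where it says the series, first, only, none or still open, it means among the compounds named here.

Measured compounds:
compound 1 `COC1Cc2c(csc2-c2ccc(C#N)cc2)C2(CCN(Cc3ccccc3)CC2)O1`: 0.25 nM
compound 2 `c1ccc(CN2CCC3(CC2)OCCc2cc(-c4ccccc4)sc23)cc1`: 2.4 nM
compound 3 `COC1Cc2cc(-c3ccccc3)sc2C2(CCN(Cc3ccccc3)CC2)O1`: 16 nM

In an assay on membranes from brain for displacement of a labelled ligand from Sigma non-opioid intracellular receptor 1 (Cavia porcellus), read by scintillation counting, with a stated time of 120 min (a higher number here means a weaker inhibitor, a lower number a stronger inhibitor), compound 3 gives the highest of the three numbers, with compound 2 nearest and compound 1 furthest away. Among the compounds with values here, the only single-point step recorded is a 6.7-fold higher number from compound 2 to compound 3 (0.82 log units; beyond the scatter); it concerns the methoxy group and does not touch the change examined here. Compound 4 `COC1Cc2cc(-c3ccc(C#N)cc3)sc2C2(CCN(Cc3ccccc3)CC2)O1` is derived from compound 3 by cyano in place of hydrogen on an aromatic carbon. Within the data shown here, no measured pair differs solely in this way, so no step bears on it directly. What the numbers show is that compound 1, which carries the cyano group, gives 0.25 nM in this assay, while compound 2, without it, gives 2.4 nM; those two compounds also differ elsewhere, so the comparison is only suggestive. On that basis compound 4 is expected to give a lower number than compound 3, a step estimated as a 6.4-fold lower number from compound 3 to compound 4 (0.81 log units; beyond the scatter). The estimate for compound 4 in this assay is 2.5 nM, with a range from 0.6 nM to 10 nM.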

Compound 4, inhibition constant: 20 nM
Compound 4: the middle estimate sits 8.0-fold (0.90 log units) below what was measured, and the stated range ends below it.
By their numbers in this assay, from the lowest: compound 1; then compound 2; then compounds 3 and 4 (each within the scatter of the next).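

In this assay, cyano in place of hydrogen on an aromatic carbon, para to a large group, gives a 1.3-fold higher number from compound 3 to compound 4 (0.10 log units; within the scatter), so on this methoxy-bearing core phenyl and 4-cyanophenyl cannot be told apart. Within the data shown here, this pair is the first to isolate the change, and it shows that the cyano group at this place does not by itself bring a lower number on this core. Nothing available explains this result.

Going by these compounds, whether the cyano group contributes anything on the core of compound 1, or on the core of compound 2, which has no methoxy group, remains open. On these data alone, it is also open whether a fluorine atom or a carboxylic acid at the same place on the phenyl ring would separate from hydrogen.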